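This account rests on a few compounds, and the source may have more. Where it says the series, first, only, none or still open, it means among the compounds named here.

Measured in a physicochemical assay for solubility, measured as kinetic solubility, at pH 2; a higher number here means a more soluble compound, a lower number a less soluble compound:
- Compound 1 `CCn1ncc2c(F)cc(-c3ccc(C(CC)(CC)c4nnc[nH]4)c(=O)[nH]3)cc21`: 39100 nM
- Compound 2 `CC(C)[C@H](C[C@H]1CCNC1=O)c1ccc(-c2ccc3cccc(F)c3c2)[nH]c1=O`: 38300 nM
- Compound 3 `CC(C)C(Cc1noc(=O)[nH]1)c1ccc(-c2ccc3cccc(F)c3c2)[nH]c1=O`: 18200 nM

Of these three numbers, the lowest belongs to compound 3, and compound 1 and compound 2 both stand higher, beyond the usual scatter. Compound 4 `CC(C)C(/C=C1\CCNC1=O)c1ccc(-c2ccc3cccc(F)c3c2)[nH]c1=O` departs from compound 3 by one change, (a group of 7 heavy atoms (5 carbon, 1 nitrogen, 1 oxygen; one five-membered non-aromatic ring with 1 hetero atom) in place of a group of 7 heavy atoms (3 carbon, 2 nitrogen, 2 oxygen; one five-membered aromatic ring with 3 hetero atoms), on a saturated chain carbon bound to an aromatic carbon and a saturated chain carbon), on a saturated chain carbon bound to an aromatic carbon and a saturated chain carbon. For the measured compounds named here, no measured pair differing in one place offers a direct guide. The nearest reference is compound 2, which also carries a five-membered non-aromatic ring with 1 hetero atom, at 38300 nM. A modest upward step in this assay is therefore expected, a 1.6-fold higher number from compound 3 to compound 4 (0.22 log units; within the scatter). For compound 4 the estimated value is 30000 nM, with an expected range from 12000 nM to 70000 nM.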

Compound 4, solubility: 23600 nM
Beside the measured number, compound 4's estimate is 1.3-fold (0.10 log units) above it, within the range that was stated.
By their numbers in this assay, from the lowest: compounds 3, 4, 2 and 1 (each within the scatter of the next, the first and the last beyond it).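

In this assay, for the compounds shown here, the first direct reading at this place is a 1.3-fold higher number from compound 3 to compound 4 (0.11 log units; within the scatter), for the five-membered non-aromatic ring with 1 hetero atom in place of the five-membered aromatic ring with 3 hetero atoms. The exchange on this saturated chain carbon thus stays within the scatter, although the entering group has 1 hydrogen-bond acceptor and the leaving group has 3. Nothing shown accounts for this result.

As far as these compounds go, whether an amine or a carboxylic acid at this place would give a step beyond the scatter remains open. A single step cannot show whether other groups would behave alike.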